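Hexyl in place of 2,5-dimethylphenyl on the acylhydrazide

This account rests on a few compounds, and the source may have more. Where it says the series, first, only, none or still open, it means among the compounds named here.

Of the compounds shown here, two sharing a core have been measured. Compound 1 `CC(C)(C)N(NC(=O)c1ccccc1)C(=O)c1ccccc1Cl` gives 75.9 nM in an assay on cells for agonist activity at ecdysone receptor (Bombyx mori), read by a luciferase reporter, with a stated time of 24 h; a lower number here means that less compound is needed, a higher number that more compound is needed for the effect. Among the compounds with values here, compound 2 `Cc1ccc(C)c(C(=O)NN(C(=O)c2ccccc2Cl)C(C)(C)C)c1` gives 1620 nM in this assay, and this is the higher of the two numbers, the only neighbour being compound 1 at a 21-fold higher number from compound 1 to compound 2 (1.33 log units; beyond the scatter). Compound 3 `CCCCCCC(=O)NN(C(=O)c1ccccc1Cl)C(C)(C)C` has yet to be measured; it differs from compound 2 in one place, (hexyl in place of 2,5-dimethylphenyl on a carbonyl carbon).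

Within the data shown here, only one measured step bears on this site, and it shows that a change of the group on that carbonyl carbon moved the number by a large amount: a 21-fold higher number from compound 1 to compound 2 (1.33 log units; beyond the scatter). Among the measured compounds shown here, no measured step exchanges a ring for a chain, so the direction for compound 3 is not fixed by the data. Given that the site is sensitive, the step for compound 3 is expected to be a 3.1-fold higher number from compound 2 to compound 3 (0.49 log units; beyond the scatter), a further rise with wide uncertainty. Compound 3 is therefore estimated at 5000 nM, with a range from 800 nM to 30000 nM in this assay.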

Compound 3, half-maximal effective concentration: 741 nM
Beside the measured number, compound 3's estimate is 6.7-fold (0.83 log units) above it; measured number outside the range, below it.
By their numbers in this assay, from the lowest: compound 1; then compound 3; then compound 2.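

In this assay, the position on the carbonyl carbon proves able to take an open chain, and a ring is not required there for the lowest number seen so far to be approached: hexyl in place of 2,5-dimethylphenyl gives a 2.2-fold lower number from compound 2 to compound 3 (0.34 log units; beyond the scatter), a modest recovery rather than a further loss. Set against the unsubstituted ring, the same chain gives a 9.8-fold higher number from compound 1 to compound 3 (0.99 log units; beyond the scatter), so the phenyl of compound 1 keeps the lowest number of the three, and the order at this site does not divide simply into rings on one side and chains on the other, as compound 3 falls between the two ring compounds. Nothing among the data shown explains this order.

The three compounds leave open how the number depends on chain length and shape, for instance whether butyl, octyl or a branched chain such as isopentyl would fall closer to compound 1 or further from it. They also leave open whether a phenyl carrying a single methyl, or a saturated cyclohexyl ring, would behave more like the phenyl of compound 1 or like the 2,5-dimethylphenyl of compound 2.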